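Notes on the series: compound 3 to compound 4

The source may hold more compounds than are shown below. What is called first, only, known or untested is meant among the compounds shown, and "the series" means these compounds.

Measured so far in a physicochemical assay for pharmacokinetics; a higher number here means that the compound lasts longer, a lower number that the compound disappears faster
compound 1 `CC(NC(=O)N1C(=O)c2ccccc2S1(=O)=O)c1ccccc1` gives 0.663 h
compound 2 `O=C(NCc1ccccc1Br)N1C(=O)c2ccccc2S1(=O)=O` gives 0.253 h
compound 3 `COc1ccc(CNC(=O)N2C(=O)c3ccccc3S2(=O)=O)cc1` gives 0.187 h

Compound 3 lies within the scatter of compound 2 and clearly under compound 1 on these numbers. Compound 4 `O=C(NCc1ccccc1F)N1C(=O)c2ccccc2S1(=O)=O` carries 2-fluorophenyl in place of 4-methoxyphenyl, on a saturated chain carbon bound to an amide-type nitrogen 2-fluorophenyl in place of 4-methoxyphenyl on a saturated chain carbon bound to an amide-type nitrogen and is not yet measured. Among the measured compounds shown here, the only measured step at this place is a 1.4-fold lower number from compound 2 to compound 3 (0.13 log units; within the scatter) and so no step beyond the scatter is expected in this assay for this change. The expected step is a 1.3-fold higher number from compound 3 to compound 4 (0.13 log units; within the scatter) and this stays within the scatter. Compound 4 is expected at 0.25 h with 0.13 h to 0.47 h as the estimated range.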

Compound 4, half-life: 0.598 h
Compound 4: middle estimate off by 2.4-fold (0.38 log units), on the low side, outside the stated range (above it).
By their numbers in this assay, from the lowest: compounds 3 and 2 (each within the scatter of the next); then compounds 4 and 1 (each within the scatter of the next).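

this assay now shows that this position can carry a change beyond the scatter, with a 3.2-fold higher number from compound 3 to compound 4 (0.50 log units; beyond the scatter) for 2-fluorophenyl in place of 4-methoxyphenyl, whereas the earlier step here stayed within it. Halogen identity also counts among these compounds, with a 2.4-fold higher number from compound 2 to compound 4 (0.37 log units; beyond the scatter) for fluoro in place of bromo on an aromatic carbon. No evidence on hand bears on the origin of either step.

Still open, from the compounds shown here alone, is how an amine or a carboxylic acid in place of 2-fluorophenyl would read in this assay on this series. Also open, going by these compounds, is whether 4-fluorophenyl would stand with compound 4 or with compound 3.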